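This account rests on a few compounds, and the source may have more. Where it says the series, first, only, none or still open, it means among the compounds named here.

Measured compounds in an ADME assay on Raji cells (Homo sapiens) for cytotoxicity, with a stated time of 72 h; on this read-out lower numbers stand for an effect already at smaller amounts and higher numbers for an effect only at larger amounts of compound:

Compound 1 `Cc1cc(NC(=O)Nc2ccccc2C(F)(F)F)c2ccccc2n1` gives > 25000 nM, which is a limit of this assay and not a number.
Compound 2 `Cc1cc(NC(=O)Nc2ccccc2F)c2ccccc2n1` gives > 25000 nM, again a limit of this assay rather than a number.
Compound 3 `Cc1cc(NC(=O)Nc2ccc(Cl)cc2)c2ccccc2n1` gives > 25000 nM, likewise only a limit of this assay.

Compound 2 thus stands at a limit in this assay, and the two further values shown are limits as well; all three sit at the limit of > 25000 nM in this assay, at which 3 of the 3 values shown sit. The step that the two limits leave unreadable from compound 1 to compound 2 and the step that the two limits leave unreadable from compound 2 to compound 3 are therefore both unreadable in size and direction.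

The unmeasured compound 4 `Cc1cc(NC(=O)Nc2ccccc2OC(F)(F)F)c2ccccc2n1` differs from compound 2 by trifluoromethoxy in place of fluoro on an aromatic carbon. Both measured steps touching compound 2 bear on this change in the loose sense that they alter substituents on the same phenyl ring, yet neither gives a readable size, so no direction in this assay can be expected from them beyond the scatter. For compound 4 the estimated step is a step that the limit leaves unreadable from compound 2 to compound 4. The value of compound 4 in this assay is expected to be about 40000 nM, in the range 15000 nM to 100000 nM, most likely reported again only as a limit.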

Compound 4, half-maximal effective concentration: > 25000 nM
Compound 4 ended at the assay's limit (the forecaster's own chance of this, stated with the estimate: 85%); the middle value lies beyond the limit too.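

Compound 4 also stands only at a limit, so neither its step from compound 2 nor its step from compound 1 can be read in this assay: the limit of > 25000 nM in this assay, at which 4 of the 4 values shown sit.

The compounds shown leave open whether any of these substituent changes alters the result in this assay at all.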